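Removing One Methoxy Group: Effect on Cytotoxicity

This account rests on a few compounds, and the source may have more. Where it says the series, first, only, none or still open, it means among the compounds named here.

Compound 1 `COc1ccc(-c2cc(/C=C/C(=O)c3ccc(N)cc3)[nH]n2)cc1` gives 92% in a functional assay on BT-549 cells (Homo sapiens) for cytotoxicity, read by sulforhodamine B assay, with a stated time of 48 h, tested at 0.01 uM; a lower number here means a stronger effect, a higher number a weaker effect of the compound at the concentration tested.
Compound 2 `COc1ccc(-c2cc(/C=C/C(=O)c3ccc(N)cc3)[nH]n2)cc1OC` gives 84% in this assay.
Compound 3 `COc1cc(C(=O)/C=C/c2cc(-c3cc(OC)c(OC)c(OC)c3)n[nH]2)cc(OC)c1OC` gives 102% in this assay.

Compound 2 and compound 1 differ in one place, (hydrogen in place of methoxy on an aromatic carbon), and the step of a number 8 percentage points higher from compound 2 to compound 1 (within the scatter). Compound 3 holds the highest of the three numbers, yet its gap to compound 1 lies within the scatter, while its gap to compound 2 lies beyond it. The difference between the cores of compound 3 and compound 2 is not broken down here. Compound 4 `COc1ccc(-c2cc(/C=C/C(=O)c3cc(OC)c(OC)c(OC)c3)[nH]n2)cc1OC` is yet to be measured in this assay. It arises from compound 3 by hydrogen in place of methoxy on an aromatic carbon, the same kind of change as that from compound 2 to compound 1; around the place, the carbon here is also meta to a methoxy group. The expected step is a number 2 percentage points higher from compound 3 to compound 4 (within the scatter), because the earlier step of a number 8 percentage points higher from compound 2 to compound 1 (within the scatter) was within the scatter. Compound 4 is estimated at 104%, between 90% and 118%.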

Compound 4, a percentage reported as activity, at one concentration (the size of the read-out at that concentration, not a potency): 96%
For compound 4 the middle estimate is 8 percentage points above the measured one; the measured number falls inside the stated range.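

In this assay, replacing methoxy with hydrogen on an aromatic carbon gives a step of a number 6 percentage points lower from compound 3 to compound 4 (within the scatter). Set beside the earlier step, the same change does not differ between the two cores: the same change on two cores in this assay, a number 8 percentage points higher (within the scatter) from compound 2 to compound 1 and a number 6 percentage points lower (within the scatter) from compound 3 to compound 4, 14 percentage points apart, within the scatter of two such steps This shows that the change carries over between these two cores without a detectable difference, but since neither step lies beyond the scatter, it shows no effect of the change on either core and says nothing about any other core.

The compounds shown leave open whether a hydroxyl group or a chlorine atom at this place would give a step beyond the scatter in this assay. They also leave open how either core would respond to a longer alkoxy chain there.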